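This account rests on a few compounds, and the source may have more. Where it says the series, first, only, none or still open, it means among the compounds named here.

Measured so far:
Compound 1, `O=C(Nc1ccc(Oc2ccnc3[nH]ccc23)cc1)c1cc2cccnc2n(-c2ccc(C(F)(F)F)cc2Cl)c1=O`: 2160 nM
Compound 2, `Cn1ccc2c(Oc3ccc(NC(=O)c4cc5cccnc5n(-c5ccc(Cl)cc5)c4=O)cc3)ccnc21`: 730 nM
Compound 3, `Cn1ccc2c(Oc3ccc(NC(=O)c4cc5cccnc5n(-c5ccc(Br)cc5)c4=O)cc3)ccnc21`: 690 nM

In a functional assay on HT-29 cells (Homo sapiens) for antiproliferative activity, read by MTT assay, with a stated time of 72 h (on this read-out higher numbers stand for weaker inhibition and lower numbers for stronger inhibition), compound 3 gives the lowest number of the three, though compound 2 stands within the scatter of it, and only compound 1 lies beyond it. Compound 4, `Cn1ccc2c(Oc3ccc(NC(=O)c4cc5cccnc5n(-c5ccc(C(F)(F)F)cc5Cl)c4=O)cc3)ccnc21`, differs from compound 3 by 2-chloro-4-(trifluoromethyl)phenyl in place of 4-bromophenyl on an aromatic nitrogen. For the measured compounds named here, no measured step covers this exact change. Going by the values given here, the only single step, a 1.1-fold lower number from compound 2 to compound 3 (0.02 log units; within the scatter), swaps one halogen for another and barely moves the number. Compound 1 carries the same entering group but also differs from compound 3 elsewhere, and its number is higher. For compound 4 a modestly higher number is therefore expected, a 1.7-fold higher number from compound 3 to compound 4 (0.24 log units; within the scatter), with the estimate for compound 4 being 1200 nM (range 450 nM to 3200 nM).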

Compound 4, half-maximal inhibitory concentration: 6050 nM
Estimate against measurement, compound 4: 5.0-fold (0.70 log units) below; measured number above the stated range.
By their numbers in this assay, from the lowest: compounds 3 and 2 (each within the scatter of the next); then compound 1; then compound 4.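

In this assay, the group on the aromatic nitrogen matters far more than the earlier halogen swap suggested: 2-chloro-4-(trifluoromethyl)phenyl in place of 4-bromophenyl gives an 8.8-fold higher number from compound 3 to compound 4 (0.94 log units; beyond the scatter) and in place of 4-chlorophenyl gives an 8.3-fold higher number from compound 2 to compound 4 (0.92 log units; beyond the scatter). With that group held fixed, methyl in place of hydrogen on an aromatic nitrogen gives a 2.8-fold higher number from compound 1 to compound 4 (0.45 log units; beyond the scatter), so that second change also counts. No measurement here accounts for these shifts. As far as these compounds go, it remains open whether the chloro or the trifluoromethyl drives the change, and how a phenyl bearing an amine or a methoxy group would read.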